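Ethyl for trifluoromethyl on the anilide ring

This account rests on a few compounds, and the source may have more. Where it says the series, first, only, none or still open, it means among the compounds named here.

Compound 1 `CCN(CC)c1ccc(NC(=O)c2c(-c3ccccc3-c3ccccc3)noc2C)cc1`: 6300 nM
Compound 2 `CCN(CC)c1ccc(NC(=O)c2c(-c3c(Cl)cccc3Cl)noc2C)c(C(F)(F)F)c1`: > 10000 nM
Compound 3 `CCN(CC)c1ccc(NC(=O)c2c(-c3c(Cl)cccc3Cl)noc2CCC2OCCCO2)c(C)c1`: 10 nM

In a functional assay on CHO K cells for inhibition of growth hormone secretagogue receptor type 1 (Homo sapiens), read by FLIPR (on this read-out lower numbers stand for stronger inhibition and higher numbers for weaker inhibition), compound 2 gives only a limit, > 10000 nM, and so stands at the weak end of the three values shown, at the limit of > 10000 nM in this assay, at which 1 of the 3 values shown sits. Compound 1 and compound 3 give numbers; compound 3 sits far toward stronger inhibition than compound 1. Compound 4 `CCc1cc(N(CC)CC)ccc1NC(=O)c1c(-c2c(Cl)cccc2Cl)noc1C` differs from compound 2 by ethyl in place of trifluoromethyl on an aromatic carbon. Going by the values given here, no pair of measured compounds differs in one place, so no measured step guides this change. Compound 4 is expected to move toward stronger inhibition, a step of an at least 6.6-fold lower number from compound 2 to compound 4 (0.82 log units; beyond the scatter), with wide uncertainty because compound 2 is known only as a limit. Compound 4 is therefore estimated at 1500 nM, between 100 nM and 10000 nM.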

Compound 4, half-maximal inhibitory concentration: 41 nM
Beside the measured number, compound 4's estimate is 37-fold (1.56 log units) above it; the measured number lies below the stated range.
By their numbers in this assay, from the lowest: compound 3; then compound 4; then compound 1. At a limit, above all of these: compound 2.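

In this assay, ethyl in place of trifluoromethyl on an aromatic carbon, ortho to a large group and meta to a diethylamino group, gives an at least 240-fold lower number from compound 2 to compound 4 (2.38 log units; beyond the scatter). Going by these compounds alone, this is the first step between compounds differing in one place, and it shows that this position alone can carry a large change in inhibition. Compound 2 gives only a limit, not a number: the limit of > 10000 nM in this assay, at which 1 of the 4 values shown sits.

The compounds shown leave open whether a longer chain, a methoxy group or chlorine at this position would match ethyl. Compound 3 carries methyl there but also differs elsewhere, so it does not settle the effect of methyl.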